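Swapping fluoro for hydroxy in a growth inhibitor

A few compounds are considered here, and "the series" means these few. Any claim that something is new, unique, unknown or untested is made for them only; others in the source may bear on it.

Compound 1 `NS(=O)(=O)c1ccc(/C=C/c2ccc(O)c(O)c2)cc1` gives 2250 nM
Compound 2 `NS(=O)(=O)c1ccc(/C=C/c2ccc(F)cc2)cc1` gives 4810 nM

In a functional assay on NCI-H522 cells (Homo sapiens) for inhibition (a lower number here means a stronger inhibitor of growth, a higher number a weaker inhibitor of growth), compound 2 (4810 nM) holds the higher of the two numbers, so it is the weaker inhibitor, and its gap to compound 1 (2250 nM) lies beyond the scatter. Compound 3 `NS(=O)(=O)c1ccc(/C=C/c2ccc(O)cc2)cc1` has hydroxy in place of fluoro on an aromatic carbon, para to a large group (hydroxy in place of fluoro on an aromatic carbon). Among the measured compounds shown here, no measured pair shows this change alone. Compound 1 (2250 nM) also carries hydroxy and sits lower than compound 2. A modest fall in the number is therefore expected (a 1.6-fold lower number from compound 2 to compound 3 (0.21 log units; within the scatter)). For compound 3 the estimated value is 3000 nM, with an expected range from 1000 nM to 9000 nM.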

Compound 3, concentration for 50% growth inhibition: 13800 nM
Compound 3: the middle estimate sits 4.6-fold (0.66 log units) below what was measured, outside the stated range (above it).
By their numbers in this assay, from the lowest: compound 1; then compound 2; then compound 3.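

In this assay, hydroxy in place of fluoro at this position is a weakening change, giving a 2.9-fold higher number from compound 2 to compound 3 (0.46 log units; beyond the scatter), so a hydroxy group here does not by itself bring the stronger inhibition of compound 1. Compound 1 carries one more hydroxy on the same ring, and hydrogen in its place gives a 6.1-fold higher number from compound 1 to compound 3 (0.79 log units; beyond the scatter), so that second hydroxy matters in this pair. No measurement at hand explains either step. The compounds shown leave open how an amine or a methoxy group would behave at this position, and how plain hydrogen would compare with fluoro and hydroxy there.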